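Swapping an Amide and a Sulfonamide for Pyrazole

The source may report more compounds than this note shows. Statements on the series, on what has been measured and on what is new or still open speak of the compounds shown alone.

Compound 1 `CNC(=O)c1cccc2c1CCC2c1ncc[nH]1` and compound 2 `CCS(=O)(=O)Nc1cccc2c1CCC2c1ncc[nH]1` share one core and differ in a single group. In a functional assay on CHO cells for agonist activity at Alpha-1B adrenergic receptor (Homo sapiens), read by FLIPR and calcium flux (on this read-out higher numbers stand for an effect only at larger amounts of compound and lower numbers for an effect already at smaller amounts), compound 1 gives > 10000 nM, which is a limit of the assay rather than a number. In this assay compound 2 likewise gives > 10000 nM, again only a limit. The step that the two limits leave unreadable from compound 1 to compound 2 therefore cannot be sized, since the limit of > 10000 nM in this assay, at which 2 of the 2 values shown sit, holds both values. Compound 3 `c1cc(-c2cn[nH]c2)c2c(c1)C(c1ncc[nH]1)CC2` is the next change from compound 2: 1H-pyrazol-4-yl in place of (ethylsulfonyl)amino on an aromatic carbon. Among the measured compounds shown here, the only measured step that touches this position is the unreadable one from compound 1 to compound 2, so it gives no direction and no size to lean on. With both anchors sitting at the limit, compound 3 is expected to remain weak, and the estimated step that the limit leaves unreadable from compound 2 to compound 3 is read as no clear change. The expected value for compound 3 in this assay is 15000 nM, within 2000 nM to 100000 nM.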

Compound 3, half-maximal effective concentration: > 10000 nM
Compound 3 was reported as a limit; the forecaster's own chance of this, stated with the estimate: 70%; the middle value lies beyond the limit too.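

In this assay, among the compounds shown here, compound 3 gives > 10000 nM, again a limit and not a number, so no step among compound 1, compound 2 and compound 3 can be read: the limit of > 10000 nM in this assay, at which 3 of the 3 values shown sit. The compounds shown leave open whether any group on this aromatic carbon gives a measurable effect in this assay.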